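Adding a (Dimethylamino)methyl Group Beside the Phenol

The source may report more compounds than this note shows. Statements on the series, on what has been measured and on what is new or still open speak of the compounds shown alone.

Measured compounds:
compound 1 `C=CC[C@@]12CCN(C(=O)OC(C)(C)C)[C@@H]1n1c3nc4ccc(O)cc4cc3c(=O)c3cccc2c31` with 32700 nM
compound 2 `CC(C)(C)OC(=O)N1CC[C@@]2(CCO)c3cccc4c(=O)c5cc6cc(O)ccc6nc5n(c34)[C@@H]12` with 26800 nM

Of the compounds shown here, two have been measured in a functional assay on NCI-H460 cells (Homo sapiens) for inhibition, read by trypan blue exclusion, with a stated time of 72 h; on this read-out lower numbers stand for stronger inhibition of growth and higher numbers for weaker inhibition of growth. Compound 1 holds the highest of the two numbers; its nearest neighbour is compound 2, and the step of a 1.2-fold lower number from compound 1 to compound 2 (0.09 log units; within the scatter) lies within the scatter, so the two show no difference that can be trusted.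

Compound 3 `C=CC[C@@]12CCN(C(=O)OC(C)(C)C)[C@@H]1n1c3nc4ccc(O)c(CN(C)C)c4cc3c(=O)c3cccc2c31` has not yet been measured. It differs from compound 1 in one place: (dimethylamino)methyl in place of hydrogen on an aromatic carbon. Among the compounds with values here, the only measured step, from compound 1 to compound 2, concerns a saturated chain on the core and not the aromatic ring where the new group enters, so no measured step bears directly on this change. Without any comparable step, the account expects no shift beyond the scatter, while allowing a wide range in either direction. Compound 3 is therefore estimated at 20000 nM, with a range from 5000 nM to 80000 nM; the step from compound 1 to compound 3 that this expectation means is a 1.6-fold lower number from compound 1 to compound 3 (0.21 log units; within the scatter).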

Compound 3, concentration for 50% growth inhibition: 17800 nM
The estimate for compound 3 lay 1.1-fold (0.05 log units) above the measured number; low and high end bracket the measured number.
By their numbers in this assay, from the lowest: compounds 3, 2 and 1 (each within the scatter of the next).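

In this assay, placing (dimethylamino)methyl in place of hydrogen on an aromatic carbon, ortho to a hydroxy group, gives a 1.8-fold lower number from compound 1 to compound 3 (0.26 log units; within the scatter), so this change produces no difference that can be trusted. Within the data shown here, this is the first reading at this aromatic carbon, since the earlier pair spoke only of a saturated chain on the core, and it shows that the position can carry this group, which brings in a nitrogen and no ring, without a shift beyond the scatter. No independent measurement is available that could explain this result or tie it to any property of the group.

From the compounds shown here alone, whether a larger group on the same aromatic carbon, such as (diethylamino)methyl or morpholinomethyl, or a shorter one, such as aminomethyl, would move the number beyond the scatter remains open. Also open, going by these compounds, is whether (dimethylamino)methyl would give a similar result on compound 2, with its hydroxymethyl in place of vinyl, or whether a methoxy group in place of the hydroxy group would alter the outcome for compound 3.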